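Tetrazole in Place of Triazole on a Short-Lived Compound

The source may hold more compounds than are shown below. What is called first, only, known or untested is meant among the compounds shown, and "the series" means these compounds.

So far, three compounds have been run in an ADME assay on microsomes from liver (Rattus norvegicus) for metabolic stability; on this read-out higher numbers stand for a longer-lived compound and lower numbers for a shorter-lived compound. Compound 1 `CC(C)C(Cc1nnc[nH]1)c1ccc(-c2ccc3cccc(F)c3c2)[nH]c1=O` gives 0.1 h, the lowest of the two plain numbers recorded. Compound 3 `CC(C)[C@H](C[C@H]1CCNC1=O)c1ccc(-c2ccc3cccc(F)c3c2)[nH]c1=O` gives 0.227 h, a higher number that lies beyond the usual scatter of this assay. Compound 2 `CCn1ncc2c(F)cc(-c3ccc(C(CC)(CC)c4nnc(C)[nH]4)c(=O)[nH]3)cc21` does not give a number but only a limit of the assay, > 3 h. That reading is the limit of > 3 h in this assay, at which 1 of the 3 values shown sits.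

Compound 4 `CC(C)C(Cc1nnn[nH]1)c1ccc(-c2ccc3cccc(F)c3c2)[nH]c1=O` has not yet been measured in this assay. It differs from compound 1 in a single place: 1H-tetrazol-5-yl in place of 4H-1,2,4-triazol-3-yl on a saturated chain carbon, two bonds along the chain from an aromatic carbon. Among the measured compounds no pair shows this exchange, so no measured step stands to guide the expectation, and the measured set gives no cause for the short half-life of compound 1 either.

In this assay the step expected a 1.5-fold higher number from compound 1 to compound 4 (0.18 log units; within the scatter) is small, within the usual scatter, with no firm direction. Compound 4 is therefore estimated to give 0.15 h in this assay, with the likely range running from 0.05 h to 0.5 h. A measurement on compound 4 will show whether this small change leaves the half-life where compound 1 sits.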

Compound 4, half-life: 2.08 h
Compound 4: the middle estimate sits 14-fold (1.14 log units) below what was measured; measured number above the stated range.
By their numbers in this assay, from the lowest: compound 1; then compound 3; then compound 4. At a limit, above all of these: compound 2.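

In this assay, putting 1H-tetrazol-5-yl in place of 4H-1,2,4-triazol-3-yl on a saturated chain carbon, two bonds along the chain from an aromatic carbon, brings a 21-fold higher number from compound 1 to compound 4 (1.32 log units; beyond the scatter). Among the compounds shown here, this is the only measured step at this position, and it shows that the half-life of compound 1 is not set by the shared core alone: the group on this chain carbon has a large say in it. The change is a small one on paper, since both groups have the same count of heavy atoms and hydrogen-bond donors and neither carries a net charge, yet one ring carbon exchanged for a nitrogen is enough to produce a step of this size.

Nothing among the compounds shown gives a measured property that accounts for the step, and the one limit recorded does not bear on it. As far as these compounds go, it remains open whether the longer half-life belongs to the tetrazole itself or would also appear with another group at this place, such as a carboxylic acid or a primary amide, and whether the same exchange would have a similar effect on a different core.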